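The compounds below may be only part of what the source reports. "The series", "measured", "known", "first", "only" and "open" are said of these compounds alone.

In a functional assay on A549 cells (Homo sapiens) for antiproliferative activity, read by MTT assay, with a stated time of 48 h (a higher number here means a weaker inhibitor, a lower number a stronger inhibitor), the three measured compounds gave these results:

Compound 1 `N#CC1=C(N)Oc2c(N)cc3nc4ccccc4nc3c2C12C(=O)N(Cc1cnnn1-c1cccc(C(F)(F)F)c1)c1ccccc12` gives 5400 nM.
Compound 2 `COc1ccccc1-n1nncc1CN1C(=O)C2(C(C#N)=C(N)Oc3c(N)cc4nc5ccccc5nc4c32)c2ccccc21` gives 37500 nM.
Compound 3 `N#CC1=C(N)Oc2c(N)cc3nc4ccccc4nc3c2C12C(=O)N(Cc1cnnn1-c1c(F)cccc1F)c1ccccc12` gives > 50000 nM, which is a limit of the assay and not a number.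

Compound 3 therefore stands at the weak end of what this assay can report: its entry is the limit (the limit of > 50000 nM in this assay, at which 1 of the 3 values shown sits), so its true value is known only as a bound. The next compound, compound 4 `N#CC1=C(N)Oc2c(N)cc3nc4ccccc4nc3c2C12C(=O)N(Cc1cnnn1-c1cc(Cl)ccc1Cl)c1ccccc12`, keeps the shared core and changes only the group hanging from the ring nitrogen: 2,5-dichlorophenyl in place of 2,6-difluorophenyl on an aromatic nitrogen.

Within the data shown here, two measured steps touch the same position. Swapping the group on that nitrogen gave an at least 9.2-fold higher number from compound 1 to compound 3 (0.96 log units; beyond the scatter) and an at least 1.3-fold higher number from compound 2 to compound 3 (0.12 log units; that floor lies within the scatter); the first is clearly beyond the scatter, while the floor of the second lies within it, so the two ortho-substituted and methoxy-bearing partners cannot be ordered against each other. A third swap at the same place, a 6.9-fold higher number from compound 1 to compound 2 (0.84 log units; beyond the scatter), shows that the group on this nitrogen does move the numbers, but all three measured values cluster at the weak end.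

With no measured partner close to 2,5-dichlorophenyl, compound 4 is expected to remain weak in this assay, at an estimated 40000 nM with a range from 12000 nM to 100000 nM. That estimate means a step of an at least 1.2-fold lower number from compound 3 to compound 4 (0.09 log units; that floor lies within the scatter), and the assay may again report only a limit.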

Compound 4, half-maximal inhibitory concentration: 10900 nM
Compound 4: middle estimate off by 3.7-fold (0.56 log units), on the high side; measured number below the stated range.
By their numbers in this assay, from the lowest: compound 1; then compound 4; then compound 2. At a limit, above all of these: compound 3.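

The entry for compound 3 in this assay is a limit of the assay and not a number: the limit of > 50000 nM in this assay, at which 1 of the 4 values shown sits.

Even against that limit, 2,5-dichlorophenyl in place of 2,6-difluorophenyl gives an at least 4.5-fold lower number from compound 3 to compound 4 (0.66 log units; beyond the scatter), and in place of 2-methoxyphenyl it gives a 3.4-fold lower number from compound 2 to compound 4 (0.54 log units; beyond the scatter), so a phenyl ring carrying two halogens is not bound to the weak end of this series, even though the leaving and entering groups have equal heavy-atom counts and neither has hydrogen-bond donors or acceptors. The 3-(trifluoromethyl)phenyl group still gives the lowest number of the four, with a 2.0-fold higher number from compound 1 to compound 4 (0.31 log units; beyond the scatter), a small step that brings a group without trifluoromethyl closer to that result than any earlier compound came.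

The compounds shown cannot separate the change of halogen, from fluorine to chlorine, from the change in where the halogens sit on the phenyl ring. On these data alone, all four groups on this nitrogen are substituted phenyl rings, so it remains open how an amine or a carboxylic acid on that ring, or a longer chain in its place, would behave.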